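A few compounds are considered here, and "the series" means these few. Any claim that something is new, unique, unknown or untested is made for them only; others in the source may bear on it.

Working notes on the series. Going by the values given here, in a functional assay on MCF7 cells (Homo sapiens) for cytotoxicity, read by MTT assay, with a stated time of 72 h (a lower number here means that less compound is tolerated, a higher number that more compound is tolerated), compound 2 `CCCCC[Se]c1nc([Se]CCCCC)c2cccnc2n1` gives 94600 nM, the only reading in the set that is a number rather than a limit. For compound 1 `COc1ccc(CNc2nc([Se]C)nc3ccccc23)cc1` the reading in this assay is a limit, > 100000 nM. For compound 3 `CCCCCSc1nc(NCc2ccc([Se]C)cc2)c2ccccc2n1` the reading in this assay is likewise a limit, > 100000 nM. Two of the three readings thus sit at the limit of > 100000 nM in this assay, at which 2 of the 3 values shown sit. Among the compounds with values here, the single number, that of compound 2, lies close to the same level.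

Compound 4 `CCCCC[Se]c1nc(N)c2cccnc2n1` has not yet been measured in this assay. It differs from compound 2 by one nitrogen atom in place of a group of 6 heavy atoms (5 carbon, 1 selenium; no ring), on an aromatic carbon. Within the data shown here, no step between measured compounds is available to set the size of this change. Given that compound 2 gives 94600 nM, the expected step of a 1.1-fold higher number from compound 2 to compound 4 (0.02 log units; within the scatter) is none beyond the scatter. A limit rather than a number may also be what is reported for compound 4. Compound 4 is accordingly estimated at 100000 nM in this assay, within 40000 nM to 300000 nM.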

Compound 4, concentration lethal to 50% of the cells: 85000 nM
For compound 4 the middle estimate is 1.2-fold (0.07 log units) above the measured one; measured number inside the range.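

Going by these compounds alone, the first step on the shared core in this assay is a 1.1-fold lower number from compound 2 to compound 4 (0.05 log units; within the scatter), so the position now has a reading, and that reading lies within the scatter. On this aromatic carbon, next to the ring nitrogen, amino can take the place of the group of 6 heavy atoms (5 carbon, 1 selenium) without a change beyond the scatter, while the same group on the other side of the ring stays in place. Both compounds of the pair give numbers, and these lie close to the level at which compound 1 and compound 3 stand as limits: the limit of > 100000 nM in this assay, at which 2 of the 4 values shown sit.

With all readings so close to that level, the step cannot tell whether this position matters for cytotoxicity in these cells. As far as these compounds go, how a morpholine, a carboxylic acid or a longer chain on this carbon would read remains open, as does the effect of amino at the other selenium-bearing carbon.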